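The source may report more compounds than this note shows. Statements on the series, on what has been measured and on what is new or still open speak of the compounds shown alone.

The series holds two pairs of compounds built around a chain that carries two amide groups and an aryl ring. Compound 1 `CCN(CC)CCNC(=O)CC(CC(=O)NC1Cc2ccccc2C1)c1ccc(Cl)cc1` and compound 2 `O=C(CC(CC(=O)NC1Cc2ccccc2C1)c1ccc(Cl)cc1)NCCN1CCCC1` share one core; compound 3 `CN(C(=O)CC(CC(=O)NCCN1CCCC1)c1ccccc1)C1Cc2ccccc2C1` and compound 4 `CCN(CC)CCNC(=O)CC(CC(=O)N(C)C1Cc2ccccc2C1)c1ccccc1` share another, and the difference between the two cores is not broken down here.

In a functional assay on HeLa cells (Homo sapiens) for inhibition (a lower number here means a stronger inhibitor, a higher number a weaker inhibitor), compound 1 gives 50500 nM. In this assay compound 2 gives 77300 nM. Between them lies the change (diethylamino in place of pyrrolidin-1-yl on a saturated chain carbon, two bonds along the chain from an amide-type nitrogen), and it produced the step of a 1.5-fold lower number from compound 2 to compound 1 (0.18 log units; within the scatter), so the two values cannot be told apart.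

For compound 3 this assay reports only a limit, > 100000 nM, which is the limit of > 100000 nM in this assay, at which 1 of the 3 values shown sits.

Compound 4 is related to compound 3 by diethylamino in place of pyrrolidin-1-yl on a saturated chain carbon, two bonds along the chain from an amide-type nitrogen. This is the same change, at the same place, that turns compound 2 into compound 1. Because a 1.5-fold lower number from compound 2 to compound 1 (0.18 log units; within the scatter) stayed within the scatter, the same exchange on the second core is expected to leave the value close to where compound 3 sits, so the expected step is a step that the limit leaves unreadable from compound 3 to compound 4. Compound 4 is therefore estimated at 120000 nM in this assay, with a plausible range from 50000 nM to 300000 nM, and a real chance that the assay again returns only a limit for compound 4 rather than a number.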

Compound 4, half-maximal inhibitory concentration: > 100000 nM
Compound 4 gave a limit, no number (the forecaster's own chance of this, stated with the estimate: 65%); the middle value does not contradict the limit.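

In this assay compound 3 and compound 4 both return a limit rather than a number, so no step between them can be read: the limit of > 100000 nM in this assay, at which 2 of the 4 values shown sit.

The compounds shown leave open whether diethylamino in place of pyrrolidin-1-yl alters the value at all on the core shared by compound 3 and compound 4, and what number either compound would give.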